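A few compounds are considered here, and "the series" means these few. Any claim that something is new, unique, unknown or untested is made for them only; others in the source may bear on it.

Measured so far in a functional assay on MDA-MB-231 cells (Homo sapiens) for cytotoxicity, read by MTT assay, with a stated time of 72 h; a lower number here means that less compound is needed, a higher number that more compound is needed for the effect:
Compound 1 `CCc1cccc2c(OC)c(-c3occ(C)c3C(=O)OC)ccc12` gives 1.3 ug/mL.
Compound 2 `CCOC(=O)c1c(C)coc1-c1ccc2c(CC)cccc2c1OC` gives 3.9 ug/mL.
Compound 3 `CCc1cccc2c(OC)c(-c3occ(C)c3C(=S)OC)ccc12` gives 5.8 ug/mL.

Compound 3 stands at the highest of the three numbers. Its nearest neighbour is compound 2, and the gap a 1.5-fold higher number from compound 2 to compound 3 (0.17 log units; within the scatter) lies within the scatter; the furthest is compound 1, and the gap a 4.5-fold higher number from compound 1 to compound 3 (0.65 log units; beyond the scatter) lies beyond it.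

Compound 4 `CCOCc1c(C)coc1-c1ccc2c(CC)cccc2c1OC` differs from compound 3 by a group of 4 heavy atoms (3 carbon, 1 oxygen; no ring) in place of a group of 4 heavy atoms (2 carbon, 1 oxygen, 1 sulfur; no ring), on an aromatic carbon. The two measured steps that touch this place are a 4.5-fold higher number from compound 1 to compound 3 (0.65 log units; beyond the scatter) and a 1.5-fold higher number from compound 2 to compound 3 (0.17 log units; within the scatter); each swaps one small group for another on the same aromatic carbon, and each moved the number by no more than a modest amount, one of them not beyond the scatter. No measured step removes the double bond outside aromatic rings that the leaving group carries, so the change to an ethoxymethyl reaches past what has been observed, and the expectation rests only on the tolerance this position has shown so far.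

Compound 4 is therefore expected to stay close to compound 3, with the expected step being a 1.2-fold lower number from compound 3 to compound 4 (0.06 log units; within the scatter). The estimate for compound 4 in this assay is 5 ug/mL, with a range from 1.5 ug/mL to 16 ug/mL.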

Compound 4, concentration for half-maximal effect: 9.1 ug/mL
Beside the measured number, compound 4's estimate is 1.8-fold (0.26 log units) below it; low and high end bracket the measured number.
By their numbers in this assay, from the lowest: compound 1; then compounds 2, 3 and 4 (each within the scatter of the next, the first and the last beyond it).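

In this assay, for the compounds shown here, ethoxymethyl is the first group at this aromatic carbon with no double bond outside aromatic rings, and the swap from the sulfur-bearing group gives a 1.6-fold higher number from compound 3 to compound 4 (0.20 log units; within the scatter), so these two compounds remain within the scatter of each other. Measured against the esters, ethoxymethyl in place of ethoxycarbonyl gives a 2.3-fold higher number from compound 2 to compound 4 (0.37 log units; beyond the scatter), and in place of methoxycarbonyl it gives a 7.0-fold higher number from compound 1 to compound 4 (0.85 log units; beyond the scatter), both beyond the scatter. With a third replacement now tested, compound 1 still needs the least compound of the series, since its steps to all three others lie beyond the scatter.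

Nothing available explains these differences. Going by these compounds, it remains open how a methoxymethyl, a longer chain, an amine or a carboxylic acid at this carbon would compare with methoxycarbonyl.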